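This account rests on a few compounds, and the source may have more. Where it says the series, first, only, none or still open, it means among the compounds named here.

Measured compounds:
- compound 1, `ClCc1ccc(Cn2cnc3c(Cl)ncnc32)cc1`: 2950 nM
- compound 2, `ClCc1ccccc1Cn1cnc2c(Cl)nc(Cl)nc21`: 1580 nM

Both compounds share a chlorinated purine-like core carrying a benzyl group that bears a chloromethyl substituent, and both were tested in a functional assay on OVCAR-5 cells (Homo sapiens) for cytotoxicity, read by sulforhodamine B assay, with a stated time of 48 h; a higher number here means a weaker inhibitor of growth, a lower number a stronger inhibitor of growth. Compound 2 gives 1580 nM, the lowest of the two numbers, and compound 1 gives 2950 nM; the gap between them lies within the scatter of repeated measurements, so nothing separates them in this assay.

Compound 3, `ClCc1ccccc1Cn1cnc2c(Cl)ncnc21`, has not yet been measured. It differs from compound 2 in a single place: hydrogen in place of chloro on an aromatic carbon. Within the data shown here, no pair of measured compounds shows this exact change, so the size of the step in this assay has to be guessed. Among the measured compounds shown here, since compound 1, which also carries only one chloro on the core, gives 2950 nM, a number close to that of compound 2, the change is expected to move the number little, if at all, beyond the scatter. The estimate for compound 3 is therefore 2500 nM, with a range from 1000 nM to 6500 nM, which corresponds to an expected step of a 1.6-fold higher number from compound 2 to compound 3 (0.20 log units; within the scatter).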

Compound 3, concentration for 50% growth inhibition: 2450 nM
For compound 3 the middle estimate is 1.0-fold (0.01 log units) above the measured one; the measured number falls inside the stated range.
By their numbers in this assay, from the lowest: compounds 2, 3 and 1 (each within the scatter of the next).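

Among these compounds, compound 2 and compound 3 are the first measured pair that differs in one place only, so the effect of this change can now be read directly instead of being inferred from less closely matched compounds. In this assay, replacing the chloro group on the aromatic carbon between two ring nitrogen atoms with hydrogen gives a 1.6-fold higher number from compound 2 to compound 3 (0.19 log units; within the scatter) and therefore produces no change that can be told apart from ordinary assay scatter, which means that growth inhibition at this level does not depend on having chloro at this position in this pair. No separate measurement is available that could explain this result.

Chloro and hydrogen are the only two groups shown at this carbon, so it remains open whether a larger or different group there, such as an amine, a methoxy group or a longer chain, would change the number. As far as these compounds go, all three compounds also keep the chloromethyl group on the benzyl ring, so what would happen with a plain methyl or a hydroxymethyl group in its place also remains open.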